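A few compounds are considered here, and "the series" means these few. Any claim that something is new, unique, unknown or untested is made for them only; others in the source may bear on it.

The study concerns three measured amides built on the shared core of compound 1 `O=C(Nc1ccc(C(F)(F)F)cc1)C1CCc2ccccc2N1` and asks what a fourth will do. In a functional assay on HCT-15 cells (Homo sapiens) for cytotoxicity, read by sulforhodamine B assay, with a stated time of 72 h (a lower number here means a stronger inhibitor of growth, a higher number a weaker inhibitor of growth), compound 1 gives 17600 nM, the only one of the three to yield a number. Compound 2 `CC(=O)N1c2ccccc2CCC1C(=O)Nc1cc(C(F)(F)F)cc(C(F)(F)F)c1` carries an acetyl group on the ring nitrogen and a bis(trifluoromethyl) anilide. In this assay compound 2 returns only a limit, > 70000 nM. Compound 3 `CCCC(=O)N1c2ccccc2CCC1C(=O)Nc1ccccc1C(F)(F)F` carries a propylcarbonyl on the same nitrogen and a single trifluoromethyl on the anilide. For compound 3 this assay likewise reports only a limit, > 70000 nM, so compound 3 stands among the two of three compounds at the edge of what the assay can resolve (the limit of > 70000 nM in this assay, at which 2 of the 3 values shown sit).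

Compound 4 `O=C(Nc1ccccc1C(F)(F)F)C1CCc2ccccc2N1` is the unmeasured partner of compound 3. The change is hydrogen in place of propylcarbonyl on a nitrogen on an aromatic ring in a ring. Among the measured compounds shown here, no measured pair isolates this change: compound 1, the only compound with a free ring nitrogen, differs from compound 3 in two places, and compound 1 at 17600 nM is the sole number available. The expected step in this assay from compound 3 to compound 4 is therefore toward a stronger inhibitor, an at least 2.8-fold lower number from compound 3 to compound 4 (0.44 log units; beyond the scatter), though the starting point is a limit and the size is uncertain. Compound 4 is estimated at 25000 nM, within a range from 8000 nM to 70000 nM.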

Compound 4, concentration for 50% growth inhibition: 40400 nM
Beside the measured number, compound 4's estimate is 1.6-fold (0.21 log units) below it; low and high end bracket the measured number.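

Among the compounds shown here, with compound 4, one change on the shared core can be read on its own for the first time: the same anilide carries either a propylcarbonyl or a hydrogen on the nitrogen on an aromatic ring in a ring. In this assay the exchange of propylcarbonyl for hydrogen at this position gives an at least 1.7-fold lower number from compound 3 to compound 4 (0.23 log units; that floor lies within the scatter) and so points toward a stronger inhibitor of growth, though the floor of this step does not by itself clear the usual scatter. The full size of the step cannot be stated because compound 3 is held at a limit of the assay and not at a number: the limit of > 70000 nM in this assay, at which 2 of the 4 values shown sit.

What the compounds shown leave open is whether a free hydrogen is specifically what matters at this nitrogen, or whether a small methyl group, a longer acyl chain or a carboxylic acid there would give a number within the range of the assay. They also leave open whether the same step would hold on the other anilides, such as the bis(trifluoromethyl) anilide of compound 2.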